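The source may report more compounds than this note shows. Statements on the series, on what has been measured and on what is new or still open speak of the compounds shown alone.

Compound 2 `CC1=CC[C@H](C(C)(C)NC(=S)N/N=C/c2ccc(Cl)cc2)CC1` gives 21100 nM in a functional assay on NCI-H460 cells (Homo sapiens) for inhibition, read by sulforhodamine B assay, with a stated time of 48 h (on this read-out higher numbers stand for weaker inhibition of growth and lower numbers for stronger inhibition of growth), and stands as the lowest of the two numbers shown, while compound 1 `CC1=CC[C@H](C(C)(C)NC(=S)N/N=C/c2cccc(Cl)c2)CC1` gives 21400 nM; the step of a 1.0-fold lower number from compound 1 to compound 2 (0.01 log units; within the scatter) lies within the scatter. Compound 3 `CC1=CC[C@H](C(C)(C)NC(=S)N/N=C/c2ccc[nH]2)CC1` differs from compound 2 by 1H-pyrrol-2-yl in place of 4-chlorophenyl on a carbon with a double bond to nitrogen. For the measured compounds named here, the only measured step merely shifts the chlorine on the same ring and says nothing about exchanging the whole ring, so no clear shift is expected in this assay. The step of a 1.2-fold higher number from compound 2 to compound 3 (0.07 log units; within the scatter) is therefore expected to stay within the scatter. Compound 3 is estimated at 25000 nM, between 8000 nM and 80000 nM.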

Compound 3, concentration for total growth inhibition: 57500 nM
Compound 3: middle estimate off by 2.3-fold (0.36 log units), on the low side; the measured number falls inside the stated range.
By their numbers in this assay, from the lowest: compounds 2 and 1 (each within the scatter of the next); then compound 3.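

Exchanging the whole ring at this position does what moving the chlorine did not: in this assay the 1H-pyrrol-2-yl group gives a 2.7-fold higher number from compound 2 to compound 3 (0.44 log units; beyond the scatter) and a 2.7-fold higher number from compound 1 to compound 3 (0.43 log units; beyond the scatter) as a modest loss of growth inhibition. The change replaces a six-membered carbon ring with a five-membered ring carrying a hydrogen-bond donor, so several features change together. No measured evidence explains this shift. From the compounds shown here alone, it remains open whether ring size or the ring nitrogen matters. A plain phenyl, a pyridin-3-yl or a furan-2-yl ring could help separate these features.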